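The compounds below may be only part of what the source reports. "The series", "measured", "known", "first", "only" and "open" are said of these compounds alone.

Measured so far in a functional assay on MKN-45 cells (Homo sapiens) for cytotoxicity, read by MTT assay, with a stated time of 72 h; a lower number here means a stronger inhibitor, a higher number a weaker inhibitor:

- compound 1 `CN(C)CCCNc1nc(-c2ccc(NC(=O)Nc3ccc(Cl)cc3)cc2)nc2c(Cl)c(Cl)sc12` gives 1530 nM
- compound 2 `CN(C)CCCNc1nc(-c2ccc(NC(=O)Nc3ccccc3Cl)cc2)nc2c(Cl)c(Cl)sc12` gives 1330 nM
- compound 3 `CCN(CC)CCCNc1nc(-c2ccc(NC(=O)Nc3ccc(Cl)cc3)cc2)nc2ccsc12` gives 180 nM

Compound 1 and compound 2 share one core and differ only in the group on the amide-type nitrogen. Compound 3 is built on a second core; how the two cores differ is not broken down here. Compound 4 `CCN(CC)CCCNc1nc(-c2ccc(NC(=O)Nc3ccccc3Cl)cc2)nc2ccsc12` carries the second core as well and has not yet been measured in this assay.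

Among the three measured compounds, compound 3 shows the lowest number. Its nearest neighbour is compound 2 and its furthest is compound 1, and both of those gaps lie beyond the scatter of repeated measurements.

The change from compound 1 to compound 2 is 2-chlorophenyl in place of 4-chlorophenyl on an amide-type nitrogen. In this assay it gave a 1.2-fold lower number from compound 1 to compound 2 (0.06 log units; within the scatter). The change from compound 3 to compound 4 is 2-chlorophenyl in place of 4-chlorophenyl on an amide-type nitrogen. Its place reads the same word for word as the earlier one, so it is the same change made on the other core. Because a 1.2-fold lower number from compound 1 to compound 2 (0.06 log units; within the scatter) did not move the number out of the scatter, the step of a 1.1-fold lower number from compound 3 to compound 4 (0.05 log units; within the scatter) is expected to be small as well; this rests on a single earlier pair and on nothing more. Compound 4 is accordingly expected to give about 160 nM in this assay, with a plausible range from 75 nM to 350 nM.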

Compound 4, half-maximal inhibitory concentration: 390 nM
Beside the measured number, compound 4's estimate is 2.4-fold (0.39 log units) below it; the measured number lies above the stated range.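

On the core of compound 3, 2-chlorophenyl in place of 4-chlorophenyl on the amide-type nitrogen gives a 2.2-fold higher number from compound 3 to compound 4 (0.34 log units; beyond the scatter) in this assay, a modest step. Set beside the same change on the core of compound 1, the two steps point in opposite directions, yet the gap between them is no larger than the scatter of two such steps allows: the same change on two cores in this assay, a 1.2-fold lower number (0.06 log units; within the scatter) from compound 1 to compound 2 and a 2.2-fold higher number (0.34 log units; beyond the scatter) from compound 3 to compound 4, 2.5-fold (0.40 log units) apart, within the scatter of two such steps. This does not show that the core alters the effect of the change, nor does it prove that the change carries over unaltered, as each core contributes a single pair and neither step has been repeated.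

Still open, going by these compounds, is whether the step on the core of compound 3 holds up with other groups on the amide-type nitrogen, such as phenyl without chlorine or 4-methoxyphenyl, and how those groups would read in this assay on each core. Also open, on these data alone, is whether the same change gives a step of similar size on a core other than these two.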